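The source may report more compounds than this note shows. Statements on the series, on what has been measured and on what is new or still open speak of the compounds shown alone.

Compound 1, `CCCCCC(=O)Nc1ccc(S(=O)(=O)Oc2ccccc2C(C)C)cc1`: in a functional assay on MCF7 cells (Homo sapiens) for antiproliferative activity, read by sulforhodamine B assay, with a stated time of 48 h (a higher number here means a weaker inhibitor, a lower number a stronger inhibitor), compound 1 gives 5300 nM.
Compound 2, `CC(C)c1ccccc1OS(=O)(=O)c1ccc(NC(=O)CCCl)cc1`: compound 2 gives 9000 nM.
Compound 3, `CCCNC(=O)Nc1ccc(S(=O)(=O)Oc2ccccc2C(C)C)cc1`: compound 3 gives 2700 nM.

Going by the values given here, compound 3 has the lowest number of the three, though the step of a 2.0-fold lower number from compound 1 to compound 3 (0.29 log units; within the scatter) leaves it and compound 1 within the scatter of each other; only the step of a 3.3-fold lower number from compound 2 to compound 3 (0.52 log units; beyond the scatter) lies beyond it. Compound 4, `CC(C)c1ccccc1OS(=O)(=O)c1ccc(NC(=O)NCC2CCCC2)cc1`, differs from compound 3 by cyclopentyl in place of ethyl on a saturated chain carbon bound to an amide-type nitrogen. Among the compounds with values here, no measured step alters this part of the chain: the steps from compound 1 and compound 2 to compound 3 change the group on the carbonyl carbon, and the step of a 1.7-fold higher number from compound 1 to compound 2 (0.23 log units; within the scatter) changes the chain tail on the amide side. On that basis compound 4 is expected to show no step beyond the scatter, a 1.2-fold lower number from compound 3 to compound 4 (0.09 log units; within the scatter). Compound 4 is estimated at 2200 nM, within 700 nM to 7000 nM.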

Compound 4, half-maximal inhibitory concentration: 7100 nM
The estimate for compound 4 lay 3.2-fold (0.51 log units) below the measured number; measured number outside the range, above it.
By their numbers in this assay, from the lowest: compounds 3, 1, 4 and 2 (each within the scatter of the next, the first and the last beyond it).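

In this assay, going by these compounds alone, this is the first change at the saturated chain carbon bound to an amide-type nitrogen, and cyclopentyl in place of ethyl weakens the compound beyond the scatter (a 2.6-fold higher number from compound 3 to compound 4 (0.42 log units; beyond the scatter)). The (cyclopentylmethyl)amino group thus loses the edge that propylamino held over 2-chloroethyl, leaving compound 4 within the scatter of both other compounds (a 1.3-fold lower number from compound 2 to compound 4 (0.10 log units; within the scatter); a 1.3-fold higher number from compound 1 to compound 4 (0.13 log units; within the scatter)). Nothing measured here explains this step.

The compounds shown do not separate the ring from the added carbons, which an open butyl chain at this carbon could test. Going by these compounds, how a phenyl group or a chain ending in an amine would behave there also remains open.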